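The source may report more compounds than this note shows. Statements on the series, on what has been measured and on what is new or still open speak of the compounds shown alone.

Compound 3 `CC(C)[C@@H]1CC[C@@H](C)C[C@@]12N(C)C(=O)[C@@H]1[C@H]3C(=O)N(c4ccc(Cl)cc4)C(=O)[C@H]3ON12` stands at the bottom of three numbers that all lie within the scatter of one another: in a functional assay, read by spectrophotometry, with a stated time of 2 h, tested at 1 mg/mL (a lower number here means a weaker effect, a higher number a stronger effect of the compound at the concentration tested), compound 3 gives 39.9%, compound 1 `CC(C)[C@@H]1CC[C@@H](C)C[C@@]12N(C)C(=O)[C@@H]1[C@H]3C(=O)NC(=O)[C@H]3ON12` gives 42.6% and compound 2 `CC(C)[C@@H]1CC[C@@H](C)C[C@@]12N(C)C(=O)[C@@H]1[C@H]3C(=O)N(C)C(=O)[C@H]3ON12` gives 41.5%. Compound 4 `Cc1cccc(N2C(=O)[C@H]3[C@H](ON4[C@@H]3C(=O)N(C)[C@@]43C[C@H](C)CC[C@H]3C(C)C)C2=O)c1` differs from compound 3 by 3-methylphenyl in place of 4-chlorophenyl on an amide-type nitrogen in a ring. Among the measured compounds shown here, the steps that bear on this exchange are the earlier changes of the group on the same nitrogen: a number 2.7 percentage points lower from compound 1 to compound 3 (within the scatter) and a number 1.6 percentage points lower from compound 2 to compound 3 (within the scatter), with a number 1.1 percentage points lower from compound 1 to compound 2 (within the scatter) as the third; none of them moves beyond the scatter. The step to compound 4 in this assay is therefore expected to stay within the scatter as well, a number 1.1 percentage points higher from compound 3 to compound 4 (within the scatter). Compound 4 is estimated at 41%, with a range from 33% to 49%.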

Compound 4, a percentage reported as activity, at one concentration (the size of the read-out at that concentration, not a potency): 25.8%
Compound 4: middle estimate off by 15.2 percentage points, on the high side; measured number outside the range, below it.
By their numbers in this assay, from the lowest: compound 4; then compounds 3, 2 and 1 (each within the scatter of the next).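

In this assay the amide-type nitrogen in a ring is not indifferent to its group: 3-methylphenyl gives a number 14.1 percentage points lower from compound 3 to compound 4 (beyond the scatter) in exchange for 4-chlorophenyl, a number 15.7 percentage points lower from compound 2 to compound 4 (beyond the scatter) in exchange for methyl and a number 16.8 percentage points lower from compound 1 to compound 4 (beyond the scatter) in exchange for hydrogen. An aromatic ring on this nitrogen does not by itself lower the number, since compound 3 stays within the scatter of compound 1 and compound 2 while compound 4 does not. No available evidence bears on the reason for this drop.

From the compounds shown here alone, whether the drop follows the methyl group itself, its place on the phenyl ring or the loss of chlorine remains open. A 4-methylphenyl or 3-chlorophenyl group on the same nitrogen would separate these readings.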